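The source may report more compounds than this note shows. Statements on the series, on what has been measured and on what is new or still open speak of the compounds shown alone.

Measured so far in a functional assay on UACC-62 cells (Homo sapiens) for antiproliferative activity, with a stated time of 48 h; on this read-out higher numbers stand for weaker inhibition of growth and lower numbers for stronger inhibition of growth:
compound 1, `Cc1cc(O)c(C2=NN(c3ccc(S(N)(=O)=O)cc3)C(/C=C/c3ccccc3)C2)cc1Cl`, gives 11400 nM
compound 2, `COc1ccc(C2CC(c3cc(Cl)c(C)cc3O)=NN2c2ccc(S(N)(=O)=O)cc2)cc1OC`, gives 12900 nM

Compound 2 and compound 1 sit within the scatter of each other in this assay: the step of a 1.1-fold higher number from compound 1 to compound 2 (0.05 log units; within the scatter) is no larger than the usual spread of repeats, so compound 2 stands with compound 1 rather than apart from it.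

Compound 3, `COc1ccc(C2CC(c3cc(Cl)c(C)cc3O)=NN2c2ccc(S(N)(=O)=O)cc2)c(OC)c1OC`, has not yet been measured in this assay. It differs from compound 2 by methoxy in place of hydrogen on an aromatic carbon; cut one bond further out, the change reads 3,4-dimethoxyphenyl to 2,3,4-trimethoxyphenyl, the new group sitting on a six-membered aromatic ring of carbon only, ortho to a methoxy group and meta to a methoxy group.

Among the measured compounds shown here, the one measured step, a 1.1-fold higher number from compound 1 to compound 2 (0.05 log units; within the scatter), exchanges the whole group on the saturated ring carbon and stays within the scatter. For the measured compounds named here, no measured step adds a methoxy to an aromatic carbon, so nothing among the measured compounds points to a change beyond the scatter. Compound 3 is expected to give 13000 nM, with a range of 5000 nM to 35000 nM. The expected step is a 1.0-fold higher number from compound 2 to compound 3 (0.00 log units; within the scatter), no larger than the scatter.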

Compound 3, concentration for total growth inhibition: 8500 nM
Beside the measured number, compound 3's estimate is 1.5-fold (0.18 log units) above it; the range from low to high includes it.
By their numbers in this assay, from the lowest: compounds 3, 1 and 2 (each within the scatter of the next).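

In this assay, methoxy in place of hydrogen on an aromatic carbon, ortho to a large group, ortho to a methoxy group and meta to a methoxy group, gives a 1.5-fold lower number from compound 2 to compound 3 (0.18 log units; within the scatter) and so does not separate compound 3 from its parent beyond repeat measurement. This position therefore takes a methoxy group, turning 3,4-dimethoxyphenyl into 2,3,4-trimethoxyphenyl, without a change that can be told from the scatter. Replacing 2-phenylethenyl with 2,3,4-trimethoxyphenyl on the saturated ring carbon gives a 1.3-fold lower number from compound 1 to compound 3 (0.13 log units; within the scatter) and also stays within the scatter, so the three compounds shown form one group in this assay, and no measured property is available to bear on this result.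

Still open, going by these compounds, is whether this position tolerates other groups, such as hydroxy, an amine, a carboxylic acid or a longer alkoxy chain, to the same degree as methoxy. The compounds shown also contain no step beyond the scatter, so they leave unsettled whether any change on this aromatic ring or on the saturated ring carbon can move growth inhibition in this series.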